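Amino Added to the Fluoropyridine of a Thiazole Acid

A few compounds are considered here, and "the series" means these few. Any claim that something is new, unique, unknown or untested is made for them only; others in the source may bear on it.

Compound 1 `O=C(O)Cc1sc(C(c2ccc(F)cc2)c2ccc(F)cc2)nc1-c1cc(F)cc(F)c1` gives 340 nM in an in vitro functional assay on HEK285-7 cells for antagonist activity at prostaglandin D2 receptor 2 (Homo sapiens), read by BRET and beta-arrestin recruitment; a higher number here means a weaker inhibitor, a lower number a stronger inhibitor.
Compound 2 `O=C(O)Cc1sc(C(c2ccc(F)cc2)c2ccc(F)cc2)nc1-c1cn[nH]c1` gives 220 nM in this assay.
Compound 3 `O=C(O)Cc1sc(C(c2ccc(F)cc2)c2ccc(F)cc2)nc1-c1ccnc(F)c1` gives 4.7 nM in this assay.

Compound 3 stands lowest of the three in this assay. Its separation from the others is large: a 72-fold lower number from compound 1 to compound 3 (1.86 log units; beyond the scatter) and a 47-fold lower number from compound 2 to compound 3 (1.67 log units; beyond the scatter), both beyond the scatter. Between compounds 1 and 2 the gap is small, a 1.5-fold lower number from compound 1 to compound 2 (0.19 log units; within the scatter), and tells nothing about order.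

Compound 4 `Nc1cc(-c2nc(C(c3ccc(F)cc3)c3ccc(F)cc3)sc2CC(=O)O)cc(F)n1` differs from compound 3 in one place: amino in place of hydrogen on an aromatic carbon. The change sits on the 2-fluoropyridin-4-yl ring that carries the whole gain from compound 1 and compound 2 to compound 3.

Within the data shown here, none of the measured steps adds a group to that ring; they swap the ring itself. They show that the aryl group at this position can move the number a great deal, but give no direction for an amino on the ring. Among the measured compounds shown here, no step within the set bears directly on the change, so no basis exists for expecting a large move in either direction in this assay.

Compound 4 is therefore expected to give about 6 nM, with a range from 1.5 nM to 25 nM, a step of a 1.3-fold higher number from compound 3 to compound 4 (0.11 log units; within the scatter) that is expected to stay within the scatter.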

Compound 4, half-maximal inhibitory concentration: 1400 nM
For compound 4 the middle estimate is 230-fold (2.37 log units) below the measured one; the measured number lies above the stated range.
By their numbers in this assay, from the lowest: compound 3; then compounds 2 and 1 (each within the scatter of the next); then compound 4.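

In this assay, a single amino next to the ring nitrogen takes away more than the 2-fluoropyridin-4-yl ring had gained: the step of a 300-fold higher number from compound 3 to compound 4 (2.47 log units; beyond the scatter) exceeds both steps that swapped the ring itself. The new 2-amino-6-fluoropyridin-4-yl ring also ends behind both earlier aryl groups, with a 6.4-fold higher number from compound 2 to compound 4 (0.80 log units; beyond the scatter) and a 4.1-fold higher number from compound 1 to compound 4 (0.61 log units; beyond the scatter) as modest steps in the same direction, so this position answers not only to which ring sits there but also to what that ring carries. Among these compounds, nothing measured here explains why this one added group moves the number so far.

On these data alone, whether the step belongs to the amino in particular or would follow any group on that carbon stays open, as a methyl, a methoxy or a dimethylamino group there could give a large step or a small one. As far as these compounds go, it is equally open whether the amino would do the same on a pyridin-4-yl ring without the fluoro group, or on the 3,5-difluorophenyl ring of the core of compound 1.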